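A few compounds are considered here, and "the series" means these few. Any claim that something is new, unique, unknown or untested is made for them only; others in the source may bear on it.

Compound 1 `CCOc1ccccc1-c1ccc(-c2nc3cnccc3c(N[C@H](CC)C(N)=O)c2C#N)cc1`, compound 2 `CC[C@@H](Nc1c(C#N)c(-c2ccc(-c3cccc(OC)c3)cc2)nc2cnccc12)C(N)=O`, compound 3 `CC[C@@H](Nc1c(C#N)c(-c2ccc(-c3ccc(F)cc3)cc2)nc2cnccc12)C(N)=O`.

In a physicochemical assay for lipophilicity, read by HPLC, at pH 7.5 (a higher number here means a more lipophilic compound, a lower number a more polar compound), compound 1 gives 3, compound 2 gives 2.7 and compound 3 gives 2.7. Compound 1 holds the highest of the three numbers, yet the steps of a number 0.30 log units lower from compound 1 to compound 2 (within the scatter) and a number 0.30 log units lower from compound 1 to compound 3 (within the scatter) are within the scatter, as is no change at the digits printed from compound 2 to compound 3 (within the scatter), so the three compounds cannot be told apart. Compound 4 `CCOc1ccccc1-c1ccc(-c2nc3cnccc3c(N[C@H](CC)C(=O)NS(=O)(=O)C3CC3)c2C#N)cc1` keeps the shared core and the 2-ethoxyphenyl of compound 1 and differs only in that (cyclopropylsulfonyl in place of hydrogen on an amide-type nitrogen). Each measured step swaps one aromatic group for another and leaves the amide untouched, so none of them bears on this change. For compound 4 the value in this assay is expected near 2, between 1.2 and 2.8. That would be an expected step of a number 1.00 log units lower from compound 1 to compound 4 (beyond the scatter).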

Compound 4, distribution coefficient: 2.3
Compound 4: middle estimate off by 0.30 log units, on the low side; low and high end bracket the measured number.
By their numbers in this assay, from the lowest: compound 4; then compounds 2, 3 and 1 (each within the scatter of the next).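

In this assay, cyclopropylsulfonyl in place of hydrogen on the amide-type nitrogen gives a number 0.70 log units lower from compound 1 to compound 4 (beyond the scatter) and so moves the reading beyond the scatter, which none of the aromatic swaps among compounds 1, 2 and 3 did. This position can therefore shift the number, at least with this group and the 2-ethoxyphenyl kept. Nothing measured here accounts for the size or direction of this step.

On these data alone, whether methylsulfonyl or acetyl on the same nitrogen would give a similar step remains open. So does whether cyclopropylsulfonyl would do the same alongside 3-methoxyphenyl or 4-fluorophenyl.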